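Sulfonyl in place of carbonyl on the shared nitrogen

This account rests on a few compounds, and the source may have more. Where it says the series, first, only, none or still open, it means among the compounds named here.

Three measured compounds share one core and differ only in the phenyl group carried on the carbonyl that sits on a nitrogen on an aromatic ring. Compound 1 `O=C(Nc1cccc(/C=C/C(=O)c2nc3ccccc3[nH]2)c1)c1cccc(Br)c1` gives 4620 nM in a functional assay on 143B cells (Homo sapiens) for antiproliferative activity, read by MTT assay, with a stated time of 48 h; a higher number here means a weaker inhibitor, a lower number a stronger inhibitor. Compound 2 `COc1ccc(C(=O)Nc2cccc(/C=C/C(=O)c3nc4ccccc4[nH]3)c2)cc1` gives 6330 nM in this assay, and compound 3 `Cc1cc(C)cc(C(=O)Nc2cccc(/C=C/C(=O)c3nc4ccccc4[nH]3)c2)c1` gives 4020 nM. The three numbers lie close together: a 1.4-fold higher number from compound 1 to compound 2 (0.14 log units; within the scatter), a 1.1-fold lower number from compound 1 to compound 3 (0.06 log units; within the scatter), and a 1.6-fold lower number from compound 2 to compound 3 (0.20 log units; within the scatter). Compound 3 has the lowest number of the three, yet its gaps to compound 1 and to compound 2 are both within the scatter, so no ordering among them can be claimed.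

Compound 4 `Cc1cccc(S(=O)(=O)Nc2cccc(/C=C/C(=O)c3nc4ccccc4[nH]3)c2)c1` differs from compound 3 in one place: (3-methylphenyl)sulfonyl in place of (3,5-dimethylphenyl)carbonyl on a nitrogen on an aromatic ring. Going by the values given here, none of the measured steps touches the carbonyl itself; each exchanges one phenyl group for another on it and stays within the scatter. Among the compounds with values here, no measured step bears on the carbonyl-to-sulfonyl exchange, so the expectation rests only on the flatness of the series so far. For compound 4 the estimate in this assay is 4500 nM, with a range from 1500 nM to 14000 nM. The expected step is a 1.1-fold higher number from compound 3 to compound 4 (0.05 log units; within the scatter), with no direction beyond the scatter anticipated.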

Compound 4, half-maximal inhibitory concentration: 791 nM
Compound 4: middle estimate off by 5.7-fold (0.76 log units), on the high side; the measured number lies below the stated range.
By their numbers in this assay, from the lowest: compound 4; then compounds 3, 1 and 2 (each within the scatter of the next).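

Going by these compounds alone, with the carbonyl on the nitrogen on an aromatic ring replaced by sulfonyl, the number in this assay moves beyond the scatter for the first time: a 5.1-fold lower number from compound 3 to compound 4 (0.71 log units; beyond the scatter), a 5.8-fold lower number from compound 1 to compound 4 (0.77 log units; beyond the scatter) and an 8.0-fold lower number from compound 2 to compound 4 (0.90 log units; beyond the scatter). Exchanging one phenyl group for another on the carbonyl left the numbers within the scatter, so this position is not flat across all changes, and compound 4 stands apart from all three carbonyl compounds. Nothing available accounts for this step.

Each step changes the aryl group along with the carbonyl, so a (3-methylphenyl)carbonyl partner for compound 4 would be needed to separate the two changes. Also open, from the compounds shown here alone, is how far the step holds with other groups on the sulfonyl, such as a simple methyl or an amine.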